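Halogen exchange on the phenyl ring of the chalcone series

The source may report more compounds than this note shows. Statements on the series, on what has been measured and on what is new or still open speak of the compounds shown alone.

Measured so far:
compound 1, `COc1cc(OC)c(C(=O)/C=C/c2ccccc2)c(OC)c1`, 2.6%
compound 2, `COc1cc(OC)c(C(=O)/C=C/c2ccc(F)cc2)c(OC)c1`, 0.7%

In a functional assay on HCT-116 cells (Homo sapiens), read by fluorescence and BrdU incorporation, with a stated time of 48 h, tested at 25 uM (on this read-out lower numbers stand for a stronger effect and higher numbers for a weaker effect at the one concentration tested), compound 2 gives 0.7%. Going by the values given here, the only neighbour with a number is compound 1, which in this assay gives 2.6%; the two numbers lie within the usual scatter of each other, so neither can be called the stronger. Both sit close to the floor of the read-out.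

Compound 3, `COc1cc(OC)c(C(=O)/C=C/c2ccc(Br)cc2)c(OC)c1`, has not been measured. It differs from compound 2 in one place: bromo in place of fluoro on an aromatic carbon. Among the compounds with values here, the one step recorded so far, a number 1.9 percentage points lower from compound 1 to compound 2 (within the scatter), is the only measured change on that aromatic carbon, and it stayed within the scatter. With compound 2 already near the floor, no further step beyond the scatter is expected in this assay; the estimated step is a number 0.8 percentage points higher from compound 2 to compound 3 (within the scatter). Compound 3 is therefore expected to give 1.5%, between 0% and 6%.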

Compound 3, a percentage reported as activity, at one concentration (the size of the read-out at that concentration, not a potency): 68%
Beside the measured number, compound 3's estimate is 66.5 percentage points below it, outside the stated range (above it).
By their numbers in this assay, from the lowest: compounds 2 and 1 (each within the scatter of the next); then compound 3.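

In this assay this aromatic carbon, para to a large group, proves sensitive to the choice of halogen: the exchange gives a number 67.3 percentage points higher from compound 2 to compound 3 (beyond the scatter), and the comparison with hydrogen gives a number 65.4 percentage points higher from compound 1 to compound 3 (beyond the scatter). Hydrogen and fluoro at this carbon remain within the scatter of each other, so the strong effect at the one concentration tested survives the first change but not the change to bromo, which leaves a much weaker effect. Nothing available gives a measured reason for this difference.

As far as these compounds go, whether chloro at the same carbon reads like fluoro or like bromo remains open, and so does the outcome with an amine there. A single concentration also leaves open how compound 3 compares with the others at any other concentration.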